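A few compounds are considered here, and "the series" means these few. Any claim that something is new, unique, unknown or untested is made for them only; others in the source may bear on it.

Measured so far in a functional assay on LNCaP cells (Prostate gland, Homo sapiens) for antiproliferative activity, read by sulforhodamine B assay; on this read-out lower numbers stand for stronger inhibition and higher numbers for weaker inhibition:
compound 1 `CCCCCCCCCCCCCCCCCCNC(=O)[C@H]1CSC(C2CCCCC2)N1`: 12800 nM
compound 2 `CCCCCCCCCCCCCCCCCCNC(=O)[C@H]1CSC(c2ccc(F)cc2)N1`: 1900 nM

Compound 1 stands highest of the two numbers in this assay; its nearest neighbour is compound 2, reached by a 6.7-fold lower number from compound 1 to compound 2 (0.83 log units; beyond the scatter). Compound 3 `CCCCCCCCCCCCCCCCCCNC(=O)[C@H]1CSC(c2c(Cl)cccc2Cl)N1` differs from compound 1 by 2,6-dichlorophenyl in place of cyclohexyl on a saturated ring carbon. Going by the values given here, the one measured step that bears on this is a 6.7-fold lower number from compound 1 to compound 2 (0.83 log units; beyond the scatter), an aromatic ring in place of cyclohexyl on a saturated ring carbon, a modest fall beyond the scatter. A step of similar size and direction is expected here: a 4.3-fold lower number from compound 1 to compound 3 (0.63 log units; beyond the scatter). Compound 3 is estimated at 3000 nM, with a range of 1000 nM to 10000 nM.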

Compound 3, half-maximal inhibitory concentration: 13100 nM
The estimate for compound 3 lay 4.4-fold (0.64 log units) below the measured number; the whole stated range lies below it.
By their numbers in this assay, from the lowest: compound 2; then compounds 1 and 3 (each within the scatter of the next).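

In this assay, an aromatic ring on this saturated ring carbon does not lower the number by itself: 2,6-dichlorophenyl in place of cyclohexyl gives a 1.0-fold higher number from compound 1 to compound 3 (0.01 log units; within the scatter) and leaves the two groups unseparated. The choice of aromatic group does count, as 2,6-dichlorophenyl in place of 4-fluorophenyl gives a 6.9-fold higher number from compound 2 to compound 3 (0.84 log units; beyond the scatter) and removes the gain seen with compound 2. No measurement at hand explains this difference between the two aromatic groups.

Open, going by these compounds, is where a plain phenyl or a pyridyl group would fall relative to compound 2 and compound 3. Also open, on these data alone, is whether a shorter chain on the amide keeps the same order.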